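The source may hold more compounds than are shown below. What is called first, only, known or untested is meant among the compounds shown, and "the series" means these compounds.

Measured so far:
compound 1 `COc1cccc(C(=O)NCCNc2cccc(NS(=O)(=O)c3cc(-c4cccc(C(=O)N(C)C)c4)ccc3OC)c2)c1`: 33 nM
compound 2 `COc1ccc(C(=O)NCCNc2cccc(NS(=O)(=O)c3cc(-c4cccc(C(=O)N(C)C)c4)ccc3OC)c2)cc1`: 1050 nM

In an assay on CHO-K1 cells for agonist activity at Orexin receptor type 2 (Homo sapiens), read by a luciferase reporter (a lower number here means that less compound is needed, a higher number that more compound is needed for the effect), compound 2 stands highest of the two numbers. Among the measured compounds shown here, the only measured step is a 32-fold higher number from compound 1 to compound 2 (1.50 log units; beyond the scatter), so the group on this carbonyl carbon moves the number strongly. Compound 3 `COc1ccc(-c2cccc(C(=O)N(C)C)c2)cc1S(=O)(=O)Nc1cccc(NCCNC(=O)c2ccccc2C)c1` differs from compound 2 by 2-methylphenyl in place of 4-methoxyphenyl on a carbonyl carbon. For the measured compounds named here, this step removes the 4-methoxyphenyl that, in the step above, came with the higher number, but no measured compound carries a 2-methylphenyl, so the expectation is uncertain. A lower number is expected, a 7.0-fold lower number from compound 2 to compound 3 (0.85 log units; beyond the scatter), short of compound 1. Compound 3 is estimated at 150 nM, between 30 nM and 800 nM.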

Compound 3, half-maximal effective concentration: 800 nM
Beside the measured number, compound 3's estimate is 5.3-fold (0.73 log units) below it; low and high end bracket the measured number.
By their numbers in this assay, from the lowest: compound 1; then compounds 3 and 2 (each within the scatter of the next).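

Removing the 4-methoxyphenyl does not by itself bring back the low number (a 1.3-fold lower number from compound 2 to compound 3 (0.12 log units; within the scatter)), so 2-methylphenyl and 4-methoxyphenyl on this carbonyl carbon are not told apart. Compound 1 stays apart (a 24-fold higher number from compound 1 to compound 3 (1.38 log units; beyond the scatter)), and of the three groups shown, only 3-methoxyphenyl goes with the low number. No evidence at hand bears on this result.

Still open, on these data alone, is whether the place of the substituent or its kind matters more: 2-methoxyphenyl and 3-methylphenyl on this carbonyl carbon would separate the two.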